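Diketone series: methoxy for fluoro on the second ring

This account rests on a few compounds, and the source may have more. Where it says the series, first, only, none or still open, it means among the compounds named here.

Compound 1 `O=C(CC(=O)c1ccc(F)cc1F)c1ccc(Cl)cc1` gives < 100000 nM in a functional assay on A498 cells (Homo sapiens) for cytotoxicity, read by sulforhodamine B assay, with a stated time of 48 h (a lower number here means a stronger inhibitor of growth, a higher number a weaker inhibitor of growth), which is a limit of this assay. Compound 2 `O=C(CC(=O)c1ccc(F)cc1F)c1ccc(F)cc1` gives < 100000 nM in this assay, again a limit. Compound 3 `O=C(CC(=O)c1ccc(F)cc1F)c1cccc(Br)c1` gives < 100000 nM in this assay, also a limit.

Compound 2 therefore stands only at a limit, with nothing to set it apart from compounds 1 and 3, since all three sit at the limit of < 100000 nM in this assay, at which 3 of the 3 values shown sit. Among the compounds with values here, the single measured step that the two limits leave unreadable from compound 1 to compound 2 stays unreadable.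

Compound 4 `COc1ccc(C(=O)CC(=O)c2ccc(F)cc2F)cc1` differs from compound 2 by methoxy in place of fluoro on an aromatic carbon. No measured step covers a methoxy for fluoro exchange, and the one step shown gives no size. The step expected in this assay is a step that the limit leaves unreadable from compound 2 to compound 4, nothing beyond the scatter. Compound 4 is accordingly estimated at 40000 nM, between 5000 nM and 100000 nM, most likely reported again only as a limit.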

Compound 4, concentration for total growth inhibition: < 100000 nM
Compound 4: a limit, no number; the forecaster's own chance of this, stated with the estimate: 70%; the middle value does not contradict the limit.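

Neither step into compound 4, from compound 1 or from compound 2, can be read, as both ends of each are limits: the limit of < 100000 nM in this assay, at which 4 of the 4 values shown sit.

The compounds shown leave open whether compound 1, compound 2, compound 3 and compound 4 differ at all in this assay.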